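Methyl to 3-bromobenzyl: an expected return to potency

The compounds below may be only part of what the source reports. "The series", "measured", "known", "first", "only" and "open" are said of these compounds alone.

Compound 2 `CCCn1c(=O)[nH]c2nc(-c3ccc(S(=O)(=O)N4CCN(C)CC4)cc3)[nH]c2c1=O` gives the higher of the two numbers measured in an assay on CHO cells for displacement of a labelled ligand from adenosine receptor A2b (Homo sapiens), read by scintillation counting, with a stated time of 75 min, in the presence of a further agent that is not named here (a lower number here means a stronger inhibitor, a higher number a weaker inhibitor), namely 48.2 nM. Among the measured compounds shown here, its only neighbour, compound 1 `CCCn1c(=O)[nH]c2nc(-c3ccc(S(=O)(=O)N4CCN(Cc5cccc(C)c5)CC4)cc3)[nH]c2c1=O`, gives 0.397 nM, and the step of a 120-fold higher number from compound 1 to compound 2 (2.08 log units; beyond the scatter) is large. Compound 3 `CCCn1c(=O)[nH]c2nc(-c3ccc(S(=O)(=O)N4CCN(Cc5cccc(Br)c5)CC4)cc3)[nH]c2c1=O` differs from compound 2 by 3-bromophenyl in place of hydrogen on a saturated chain carbon bound to an amine nitrogen in a ring. For the measured compounds named here, the one measured step that bears on this change is a 120-fold higher number from compound 1 to compound 2 (2.08 log units; beyond the scatter), and read in the opposite direction it points to a large fall in the number. The expected step is therefore a 96-fold lower number from compound 2 to compound 3 (1.98 log units; beyond the scatter). Compound 3 is estimated at 0.5 nM in this assay, within a range of 0.15 nM to 2 nM.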

Compound 3, inhibition constant: 0.148 nM
Compound 3: the middle estimate sits 3.4-fold (0.53 log units) above what was measured; the measured number lies below the stated range.
By their numbers in this assay, from the lowest: compound 3; then compound 1; then compound 2.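

In this assay, the change from methyl to 3-bromobenzyl gives a 330-fold lower number from compound 2 to compound 3 (2.51 log units; beyond the scatter), so the large gain at this saturated chain carbon is not confined to the 3-methylphenyl group of compound 1. The aromatic substituent also matters: bromo in place of methyl on an aromatic carbon gives a 2.7-fold lower number from compound 1 to compound 3 (0.43 log units; beyond the scatter), a modest step but one beyond the scatter. No available evidence accounts for either step.

The compounds shown leave open how an unsubstituted phenyl would compare with these groups. They also leave open how chloro, methoxy or an amine would read on that aromatic carbon.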